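This account rests on a few compounds, and the source may have more. Where it says the series, first, only, none or still open, it means among the compounds named here.

Values in an assay on brain for displacement of a labelled ligand from D(3) dopamine receptor (Rattus norvegicus) (a higher number here means a weaker inhibitor, a lower number a stronger inhibitor), for the measured members of the series:

compound 1 `CCCN(CC[C@H]1CC[C@H](NC(=O)c2cccc3ncccc23)CC1)[C@H]1CCc2nc(N)sc2C1` — 1.6 nM
compound 2 `CCCN(CC[C@H]1CC[C@H](NC(=O)c2ccc(-n3ccnc3)cc2)CC1)[C@H]1CCc2nc(N)sc2C1` — 1.9 nM
compound 3 `CCCN(CC[C@H]1CC[C@H](NC(=O)c2ccc(-c3noc(C)n3)cc2)CC1)[C@H]1CCc2nc(N)sc2C1` — 1.3 nM

Compound 3 carries the lowest of the three numbers, but the separation is slight: the step of a 1.2-fold lower number from compound 1 to compound 3 (0.09 log units; within the scatter) and the step of a 1.5-fold lower number from compound 2 to compound 3 (0.16 log units; within the scatter) both sit within the scatter, as does a 1.2-fold higher number from compound 1 to compound 2 (0.07 log units; within the scatter). All three swaps of the group on the carbonyl carbon leave this assay essentially unmoved.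

Compound 4 `CCCN(CC[C@H]1CC[C@H](NC(=O)c2ccc(-c3noc(C4CC4)n3)cc2)CC1)[C@H]1CCc2nc(N)sc2C1` is the next member to be measured. It differs from compound 3 by cyclopropyl in place of methyl on an aromatic carbon. For the measured compounds named here, no measured step touches this methyl position; the only steps available concern the whole group on the carbonyl carbon, and each of those stayed within the scatter. On that basis a step beyond the scatter is not expected for compound 4, and the expected change is a 1.2-fold higher number from compound 3 to compound 4 (0.06 log units; within the scatter). In this assay compound 4 is estimated at 1.5 nM, with an expected range from 0.7 nM to 3.5 nM.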

Compound 4, inhibition constant: 3.5 nM
Estimate against measurement, compound 4: 2.3-fold (0.37 log units) below; the measured number falls inside the stated range.
By their numbers in this assay, from the lowest: compounds 3, 1, 2 and 4 (each within the scatter of the next, the first and the last beyond it).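

In this assay, for the compounds shown here, the methyl position on the five-membered aromatic ring gives the first step beyond the scatter, a modest one (a 2.7-fold higher number from compound 3 to compound 4 (0.43 log units; beyond the scatter)), whereas every swap of the whole group on the carbonyl carbon stayed within it. The comparison with the 1H-imidazol-1-yl compound stays within the scatter (a 1.8-fold higher number from compound 2 to compound 4 (0.27 log units; within the scatter)), so the loss is visible against the methyl partner but does not separate compound 4 from compound 2. No available evidence bears on why cyclopropyl in place of methyl moves the number.

Only methyl and cyclopropyl appear on this aromatic carbon, so the result rests on a single pair. Where an ethyl, an isopropyl, a tert-butyl or an amine at this carbon would fall relative to these two remains open.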